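This account rests on a few compounds, and the source may have more. Where it says the series, first, only, none or still open, it means among the compounds named here.

Three compounds frame the question, and all of them sit at the weak end of a functional assay on MDA-MB-453 cells (Homo sapiens) for cytotoxicity, read by MTT assay, with a stated time of 48 h; a lower number here means a stronger inhibitor, a higher number a weaker inhibitor. In this assay compound 1 `COc1cc(C#N)ccc1OCc1nnc(-c2ccccc2)o1` gives 40200 nM, and compound 2 `COc1ccc(-c2nnc(COc3ccc(C#N)c(F)c3)o2)cc1` gives 45500 nM, two values that lie within the scatter of each other. Compound 3 `c1ccc(-c2nnc(COc3ccc(-c4nnco4)cc3)o2)cc1` returns no number, only the limit > 50000 nM. Its exact position in this assay is therefore unknown.

Compound 4 `Clc1ccc(-c2nnc(COc3ccc(-c4nnco4)cc3)o2)cc1` differs from compound 3 in one place: chloro in place of hydrogen on an aromatic carbon. Seen one bond further out, phenyl becomes 4-chlorophenyl. No measured pair among these compounds shows such a change, so its size in this assay can only be judged from the overall range. For the measured compounds named here, the only numbers available, compound 1 at 40200 nM and compound 2 at 45500 nM, are both weak, so a large gain is not expected. A small move toward stronger inhibition is the likeliest outcome, and it may not clear the scatter. The expected step, an at least 1.2-fold lower number from compound 3 to compound 4 (0.09 log units; that floor lies within the scatter), is correspondingly modest, and another bare limit would be no surprise. In this assay compound 4 is estimated at 40000 nM, with an expected range from 18000 nM to 70000 nM.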

Compound 4, half-maximal inhibitory concentration: > 50000 nM
Compound 4: no number, only a limit (the forecaster's own chance of this, stated with the estimate: 45%); at least 1.2-fold (0.09 log units) between middle value and limit.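

In this assay, for the compounds shown here, compound 4 returns only a limit, > 50000 nM, so no step from compound 3, which also gave only a limit, can be read. The two compounds stop at the same limit: the limit of > 50000 nM in this assay, at which 2 of the 4 values shown sit.

The compounds shown leave open what chloro in place of hydrogen does here, and where compound 3 and compound 4 truly stand.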